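A methoxy group added to a weak growth inhibitor

The source may report more compounds than this note shows. Statements on the series, on what has been measured and on what is new or still open speak of the compounds shown alone.

- compound 1 `c1ccc(-c2ccc(-c3ccc(-c4nc5ccccc5[nH]4)cc3)cc2)cc1`: 41200 nM
- compound 2 `Cc1ccc2[nH]c(-c3ccc(-c4ccc(-c5ccc(N(C)C)cc5)cc4)cc3)nc2c1`: 3510 nM

In a functional assay on A549 cells (Homo sapiens) for inhibition, read by sulforhodamine B assay (a higher number here means a weaker inhibitor of growth, a lower number a stronger inhibitor of growth), compound 1 gives 41200 nM, the higher of the two numbers and therefore the weaker inhibitor of growth. Compound 2 gives 3510 nM, and the gap between the two lies beyond the usual scatter of repeated measurements. These two compounds differ in more than one place, so no single change has a measured size yet.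

Compound 3 `COc1ccc(-c2ccc(-c3ccc(-c4nc5ccccc5[nH]4)cc3)cc2)cc1` keeps the core of compound 1 and changes one group: methoxy in place of hydrogen on an aromatic carbon. This is methoxy in place of hydrogen on an aromatic carbon, or phenyl to 4-methoxyphenyl. Compound 2, which also carries added groups, stands at 3510 nM, so a modest move towards a lower number is expected. The expected step is a 2.3-fold lower number from compound 1 to compound 3 (0.36 log units; beyond the scatter). For compound 3 the estimate is 18000 nM, with an expected range of 5000 nM to 60000 nM.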

Compound 3, concentration for 50% growth inhibition: 38100 nM
Compound 3: the middle estimate sits 2.1-fold (0.33 log units) below what was measured, and the stated range covers the measured number.
By their numbers in this assay, from the lowest: compound 2; then compounds 3 and 1 (each within the scatter of the next).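

Methoxy in place of hydrogen on an aromatic carbon, para to a large group, gives the first single change with a measured size here: a 1.1-fold lower number from compound 1 to compound 3 (0.03 log units; within the scatter) in this assay. Compound 1 and compound 3 therefore cannot be told apart by this read-out, so at this position, the swap from phenyl to 4-methoxyphenyl leaves growth inhibition where it stood. Nothing available here says why this group makes so little difference.

Still open, going by these compounds, is whether a different group at the same place, such as an amine, a hydroxyl or a carboxylic acid, would give a number clearly different from that of compound 1. A longer chain on the oxygen, such as ethoxy or propoxy, poses the same open question.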